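A few compounds are considered here, and "the series" means these few. Any claim that something is new, unique, unknown or untested is made for them only; others in the source may bear on it.

Among the measured compounds shown here, in a physicochemical assay for solubility, read by LC-MS, in phosphate buffer, with a stated time of 24 h, at pH 7.4 (a lower number here means a less soluble compound, a higher number a more soluble compound), compound 1 `Cc1nc(CO)ccc1-c1cnc(NCc2c(F)ccc3c2CCO3)c2cn[nH]c(=O)c12` gives 3000 nM, while compound 2 `CNC(=O)c1ccc(-c2cnc(NCc3c(F)ccc4c3CCO4)c3cn[nH]c(=O)c23)c(C)n1` gives 19000 nM, the higher of the two numbers so far. Compound 3 `Cc1nc(C(=O)N(C)C)ccc1-c1cnc(NCc2c(F)ccc3c2CCO3)c2cn[nH]c(=O)c12` differs from compound 2 in one place: methyl in place of hydrogen on an amide-type nitrogen, which turns methylcarbamoyl into dimethylcarbamoyl. For the measured compounds named here, only one measured step bears on this. Methylcarbamoyl in place of hydroxymethyl on an aromatic carbon gave a 6.3-fold higher number from compound 1 to compound 2 (0.80 log units; beyond the scatter), a modest move that exchanged a whole group. Here the amide stays and only a single methyl is added, so a step smaller than a 6.3-fold higher number from compound 1 to compound 2 (0.80 log units; beyond the scatter) is expected, probably within the scatter and with no firm direction. The expected step is a 1.2-fold higher number from compound 2 to compound 3 (0.08 log units; within the scatter). Compound 3 is estimated at 23000 nM, with an expected range of 8000 nM to 60000 nM.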

Compound 3, solubility: 403000 nM
Compound 3: the middle estimate sits 18-fold (1.24 log units) below what was measured, outside the stated range (above it).
By their numbers in this assay, from the lowest: compound 1; then compound 2; then compound 3.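

In this assay the amide nitrogen proves to be a sensitive place: a single methyl in place of hydrogen, which turns methylcarbamoyl into dimethylcarbamoyl, gives a 21-fold higher number from compound 2 to compound 3 (1.33 log units; beyond the scatter) and so outruns the earlier exchange of a whole group. Dimethylcarbamoyl in place of hydroxymethyl on the aromatic carbon gives a 130-fold higher number from compound 1 to compound 3 (2.13 log units; beyond the scatter) with the rest of the structure unchanged, so the group at this one place can shift the number widely. No measurement at hand explains why one added carbon matters so much.

The compounds shown cannot separate the effect of the added methyl from that of losing the amide hydrogen. From the compounds shown here alone, it also remains open whether an ethyl group on this nitrogen, or a ring amide such as a morpholine amide, would give a step of similar size.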